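Unbound fraction of the benzylic epimer of compound 1

The compounds below may be only part of what the source reports. "The series", "measured", "known", "first", "only" and "open" are said of these compounds alone.

The series shares one core, carried by compound 1 `CC[C@H](c1ccc(C(=O)O)c(Oc2cccc(Cl)c2)c1OC)N1CCC[C@H](n2cc(C)c(=O)[nH]c2=O)C1`. In an ADME assay on a cell-free system (plasma, Homo sapiens) for protein binding, using equilibrium dialysis, with a stated time of 5 h, tested at 10 uM (a lower number here means a smaller unbound share, a higher number a larger unbound share of the compound), compound 1 gives 0.015, the lowest of the two numbers in hand. Compound 2 `CC[C@H](c1ccc(C(=O)O)c(Oc2cccc(Cl)c2)c1F)N1CCC[C@H](n2cc(C)c(=O)[nH]c2=O)C1` exchanges fluoro for methoxy on an aromatic carbon; in this assay compound 2 gives < 0.01, which is a limit of the assay and not a number. The step is an at least 1.5-fold lower number from compound 1 to compound 2 (0.17 log units; that floor lies within the scatter). Compound 3 `CCC[C@H](c1ccc(C(=O)O)c(Oc2cccc(Cl)c2)c1OC)N1CCC[C@H](n2cc(C)c(=O)[nH]c2=O)C1` carries methyl in place of hydrogen on a saturated chain carbon, three bonds along the chain from an amine nitrogen in a ring and an aromatic carbon; in this assay compound 3 gives 0.034, and the step is a 2.3-fold higher number from compound 1 to compound 3 (0.36 log units; beyond the scatter).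

Compound 4 `CC[C@@H](c1ccc(C(=O)O)c(Oc2cccc(Cl)c2)c1OC)N1CCC[C@H](n2cc(C)c(=O)[nH]c2=O)C1` is not yet measured. It differs from compound 1 only in configuration: the two compounds have the same atoms and bonds and differ only in configuration as drawn: 1 of 2 stereo elements differ; a stereocentre at a saturated chain carbon is drawn R in compound 1 and S in compound 4. Neither measured step bears directly on an inversion of a stereocentre; both change the atoms present, whereas here nothing leaves and nothing enters. Without a stereochemical precedent among the measured compounds, the account expects no step beyond the scatter, so that no change at the digits printed from compound 1 to compound 4 (within the scatter) is the estimated change. Compound 4 is therefore expected to give about 0.015, estimated between 0.007 and 0.035, with the possibility that the assay returns only a limit as it did once already (the limit of < 0.01 in this assay, at which 1 of the 3 values shown sits).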

Compound 4, unbound fraction: 0.11
For compound 4 the middle estimate is 7.3-fold (0.87 log units) below the measured one, and the stated range ends below it.
By their numbers in this assay, from the lowest: compound 1; then compound 3; then compound 4. At a limit, below all of these: compound 2.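

In this assay, the configuration at this saturated chain carbon matters on its own: with the stereocentre drawn S in place of R, the result is a 7.3-fold higher number from compound 1 to compound 4 (0.87 log units; beyond the scatter). The earlier steps shown here each changed the atoms present, one on an aromatic carbon and one on the chain, and neither could show that inversion alone, with the same atoms and bonds, moves the unbound fraction beyond the scatter. The shift can be assigned to this stereocentre and to nothing else, because nothing leaves and nothing enters: the fact that compounds 1 and 4 differ only in the configuration as drawn.

The compounds shown leave open whether the same inversion raises the unbound fraction when the chain on that carbon is the longer one of compound 3, or when fluoro stands in place of methoxy as in compound 2. They also leave open how an isopropyl or a cyclopropyl group on this carbon would fare in either configuration, and what inversion of the second stereocentre, drawn alike in all of them, would do.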